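Chain-lengthening in the aminodiol series: next homologue

The compounds below may be only part of what the source reports. "The series", "measured", "known", "first", "only" and "open" are said of these compounds alone.

Compound 2 `CCCCCCCCCCCCc1ccc(CCC(N)(CO)CO)cc1` gives 0.1 mg/kg in a functional assay on the whole organism with Rattus norvegicus as the target; on this read-out lower numbers stand for an effect already at smaller amounts and higher numbers for an effect only at larger amounts of compound; compound 1 `CCCCCCCCCc1ccc(CCC(N)(CO)CO)cc1` gives 0.03 mg/kg. Among the compounds with values here, compound 2 thus stands highest of the two numbers, the nearest being compound 1, and the only measured step, a 3.3-fold higher number from compound 1 to compound 2 (0.52 log units; beyond the scatter), bears directly here. Compound 3 `CCCCCCCCCCCCCc1ccc(CCC(N)(CO)CO)cc1` carries the change (methyl in place of hydrogen on a saturated chain carbon, ten or more bonds along the chain from an aromatic carbon). A single methyl is a smaller extension than the propyl of that step, so a smaller shift in the same direction is expected, likely near the scatter. The expected step is a 1.5-fold higher number from compound 2 to compound 3 (0.18 log units; within the scatter), giving for compound 3 an estimated 0.15 mg/kg, within 0.07 mg/kg to 0.35 mg/kg.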

Compound 3, dose for 50% inhibition: 0.03 mg/kg
Compound 3: middle estimate off by 5.0-fold (0.70 log units), on the high side, and the stated range ends above it.
By their numbers in this assay, from the lowest: compounds 1 and 3 (each within the scatter of the next); then compound 2.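

In this assay, methyl in place of hydrogen on a saturated chain carbon, ten or more bonds along the chain from an aromatic carbon, gives a step opposite in direction to the earlier one (a 3.3-fold lower number from compound 2 to compound 3 (0.52 log units; beyond the scatter)). The longer chain of compound 3 shows no change at the digits printed from compound 1 to compound 3 (within the scatter), so the number does not rise steadily with chain length, and compound 3 goes against any such pattern. No measured evidence bears on this turn in the read-out. On these data alone, whether a longer chain holds this level stays open, as does how a carboxylic acid or an amine would read in place of the added methyl.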